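The compounds below may be only part of what the source reports. "The series", "measured", "known", "first", "only" and "open" are said of these compounds alone.

In a functional assay on NCI-H322M cells (Homo sapiens) for inhibition, read by sulforhodamine B assay, with a stated time of 48 h (a higher number here means a weaker inhibitor of growth, a lower number a stronger inhibitor of growth), the measured compounds give these values:
- compound 1 `COc1cc(-c2nn(-c3cccc(NC(=O)Nc4cc(C(F)(F)F)cc(C(F)(F)F)c4)c3)cc2-c2ccncc2)ccc1Cl` gives 1020 nM
- compound 2 `COc1cc(-c2nn(-c3cccc(NC(=O)c4cccc(C(F)(F)F)c4)c3)cc2-c2ccncc2)ccc1Cl` gives 10800 nM
- compound 3 `COc1cc(-c2nn(-c3cccc(NC(=O)Nc4ccc(Cl)c(Cl)c4)c3)cc2-c2ccncc2)ccc1Cl` gives 1690 nM

Compound 1 and compound 3 lie within the scatter of each other, while compound 2 has a higher number than compound 1, beyond the scatter. Compound 4 `COc1cc(-c2nn(-c3cccc(NC(=O)Nc4cccc(C(F)(F)F)c4)c3)cc2-c2ccncc2)ccc1Cl` is compound 1 with a single change: hydrogen in place of trifluoromethyl on an aromatic carbon. Going by the values given here, the one measured step, a 6.4-fold lower number from compound 2 to compound 3 (0.81 log units; beyond the scatter), swaps the whole group on the carbonyl carbon, so it bears on this change only loosely. Among the compounds with values here, no measured step removes a trifluoromethyl alone. The closest guide is compound 3, which has no trifluoromethyl on that ring and gives 1690 nM, within the scatter of compound 1. The estimated change is a 2.0-fold higher number from compound 1 to compound 4 (0.29 log units; within the scatter) in this assay and points to a somewhat weaker inhibitor of growth, close to the scatter. Compound 4 is therefore estimated at 2000 nM (expected range 900 nM to 5000 nM).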

Compound 4, concentration for 50% growth inhibition: 1210 nM
Compound 4: the middle estimate sits 1.7-fold (0.22 log units) above what was measured; the measured number falls inside the stated range.
By their numbers in this assay, from the lowest: compounds 1, 4 and 3 (each within the scatter of the next); then compound 2.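

In this assay, the step that removes one trifluoromethyl group alone is a 1.2-fold higher number from compound 1 to compound 4 (0.07 log units; within the scatter), so at this aromatic carbon hydrogen and trifluoromethyl cannot be told apart. Changing the whole ring gives a 1.4-fold lower number from compound 3 to compound 4 (0.15 log units; within the scatter), so 3-(trifluoromethyl)phenyl and 3,4-dichlorophenyl on the amide-type nitrogen cannot be told apart either. The clearest new result concerns the link rather than the ring: with 3-(trifluoromethyl)phenyl held constant, adding the amino group on the carbonyl carbon gives an 8.9-fold lower number from compound 2 to compound 4 (0.95 log units; beyond the scatter), a change that the earlier comparison could not separate from a change of ring substituents.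

No available measurement explains these numbers. As far as these compounds go, it remains open whether this aromatic carbon would accept a more different group, such as an amine or a carboxylic acid, without moving the number beyond the scatter.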